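The compounds below may be only part of what the source reports. "The series", "measured", "known", "first", "only" and "open" are said of these compounds alone.

Compound 1, `Cc1ccccc1-n1nncc1CN1C(=O)C2(C(C#N)=C(N)Oc3c(N)cc4nc5ccccc5nc4c32)c2ccccc21`: in an ADME assay on L02 cells (Homo sapiens) for antiproliferative activity, read by MTT assay, with a stated time of 48 h (a higher number here means a weaker inhibitor, a lower number a stronger inhibitor), compound 1 gives > 50000 nM, which is a limit of the assay.
Compound 2, `N#CC1=C(N)Oc2c(N)cc3nc4ccccc4nc3c2C12C(=O)N(Cc1cnnn1-c1ccccc1Br)c1ccccc12`: in this assay compound 2 gives 29200 nM.

Within the data shown here, compound 2 holds the only number; compound 1 sits at the limit of > 50000 nM in this assay, at which 1 of the 2 values shown sits. Among the measured compounds shown here, the single measured step, an at least 1.7-fold lower number from compound 1 to compound 2 (0.23 log units; that floor lies within the scatter), came with bromo in place of methyl. Compound 3, `CCOc1ccccc1-n1nncc1CN1C(=O)C2(C(C#N)=C(N)Oc3c(N)cc4nc5ccccc5nc4c32)c2ccccc21`, carries ethoxy in place of bromo on an aromatic carbon. For the measured compounds named here, no measured step involves ethoxy, and the one step at this position stayed within the scatter, so no change beyond the scatter is expected. Compound 3 is expected to give 30000 nM, between 12000 nM and 80000 nM. The expected step is a 1.0-fold higher number from compound 2 to compound 3 (0.01 log units; within the scatter).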

Compound 3, half-maximal inhibitory concentration: > 50000 nM
Compound 3: only a limit was reported; the forecaster's own chance of this, stated with the estimate: 35%; middle value at least 1.6-fold (0.22 log units) away from the limit.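

Going from 2-bromophenyl to 2-ethoxyphenyl gives an at least 1.7-fold higher number from compound 2 to compound 3 (0.23 log units; that floor lies within the scatter). Compound 3 gives only a limit of the assay, as compound 1 does, so the step between those two cannot be read: the limit of > 50000 nM in this assay, at which 2 of the 3 values shown sit. Bromo is thus the only one of the three groups at this place with a real number, and neither readable step goes beyond the scatter.

The compounds shown leave open whether an amine or a carboxylic acid in place of bromo would give a number clearly lower than that of compound 2. On these data alone, whether a longer chain than ethoxy would also stay at the limit remains open too.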